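Bromo for Trifluoromethyl on a Shared Core

This account rests on a few compounds, and the source may have more. Where it says the series, first, only, none or still open, it means among the compounds named here.

Compound 1 `Fc1ccc(-c2nc3ccccn3c2NC2CCCCC2)cc1` in an assay on membranes from brain for displacement of a labelled ligand from adenosine receptor A1 (Rattus norvegicus); on this read-out higher numbers stand for weaker inhibition and lower numbers for stronger inhibition: > 100000 nM, a limit of the assay.
Compound 2 `Cc1ccc(-c2nc3ccccn3c2NC2CCCCC2)cc1` in this assay: 2060 nM.
Compound 3 `FC(F)(F)c1ccc(-c2nc3ccccn3c2NC2CCCCC2)cc1` in this assay: > 100000 nM, a limit of the assay.

Compound 3 stands at the limit of > 100000 nM in this assay, at which 2 of the 3 values shown sit, so no number is known for it, only that it lies past that point. Compound 4 `Brc1ccc(-c2nc3ccccn3c2NC2CCCCC2)cc1` differs from it by bromo in place of trifluoromethyl on an aromatic carbon. Among the compounds with values here, two measured steps touch the same position. The first is an at least 48-fold higher number from compound 2 to compound 3 (1.68 log units; beyond the scatter), and the second is an at least 48-fold lower number from compound 1 to compound 2 (1.68 log units; beyond the scatter); the step that the two limits leave unreadable from compound 1 to compound 3 cannot be read, as both ends are limits. Methyl gave a readable number while fluoro and trifluoromethyl both fell to the limit, and bromo is neither of these groups, so the direction is uncertain. The step is expected to be an at least 5.0-fold lower number from compound 3 to compound 4 (0.69 log units; beyond the scatter), with a real chance that the value stays at the limit. Compound 4 is therefore estimated at 20000 nM, in the range 2000 nM to 200000 nM.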

Compound 4, inhibition constant: 3900 nM
For compound 4 the middle estimate is 5.1-fold (0.71 log units) above the measured one; measured number inside the range.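

Swapping trifluoromethyl for bromo on the aromatic carbon para to a large group gives a readable number in this assay, with an at least 25-fold lower number from compound 3 to compound 4 (1.40 log units; beyond the scatter), and the change from fluoro gives an at least 25-fold lower number from compound 1 to compound 4 (1.40 log units; beyond the scatter). Against methyl, the change is a 1.9-fold higher number from compound 2 to compound 4 (0.28 log units; within the scatter), so bromo and methyl cannot be told apart at this position. A readable number is therefore no longer confined to methyl: among the groups shown here, methyl and bromo give one, while fluoro and trifluoromethyl do not.

How far compounds 1 and 3 truly lie from the others stays open, because both sit at a limit: the limit of > 100000 nM in this assay, at which 2 of the 4 values shown sit.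

On these data alone, whether an amine, a carboxylic acid or a longer chain at this position would give a number clearly lower than those of compounds 2 and 4 also remains open.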